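Cyclohexyl to isopropyl: the step to compound 4

The source may report more compounds than this note shows. Statements on the series, on what has been measured and on what is new or still open speak of the compounds shown alone.

Measured in a functional assay on KB-V1 cells (Homo sapiens) for cytotoxicity, read by MTT assay, with a stated time of 72 h (on this read-out higher numbers stand for weaker inhibition and lower numbers for stronger inhibition), the three compounds read as follows:
compound 1 `O=C1Nc2ccccc2/C1=N/NC(=S)Nc1cccc2ccccc12` gives 2210 nM
compound 2 `O=C1Nc2ccccc2/C1=N/NC(=S)Nc1ccccc1` gives 1470 nM
compound 3 `O=C1Nc2ccccc2/C1=N/NC(=S)NC1CCCCC1` gives 4380 nM

The account now turns to compound 3, whose value of 4380 nM lies within the scatter of compound 1 but beyond the scatter of compound 2. Compound 4 `CC(C)NC(=S)N/N=C1\C(=O)Nc2ccccc21` has not yet been measured. It differs from compound 3 in one place, with isopropyl in place of cyclohexyl on an amide-type nitrogen as the counted change, which is isopropyl in place of cyclohexyl on an amide-type nitrogen.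

Among the measured compounds shown here, only one measured step bears on this change, and it does so indirectly. That step is a 3.0-fold higher number from compound 2 to compound 3 (0.47 log units; beyond the scatter) and it is modest, yet it exchanges phenyl for cyclohexyl and involves no isopropyl group. For the measured compounds named here, no measured pair replaces cyclohexyl with an open chain, so the evidence for a direction is thin. A step beyond the scatter is therefore not expected in this assay for this change. The estimate is a 1.1-fold higher number from compound 3 to compound 4 (0.06 log units; within the scatter) and this expected step stays within the scatter. For compound 4 the expected value is 5000 nM with an estimated range from 2000 nM to 12000 nM as its limits.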

Compound 4, half-maximal inhibitory concentration: 10300 nM
Beside the measured number, compound 4's estimate is 2.1-fold (0.31 log units) below it; measured number inside the range.
By their numbers in this assay, from the lowest: compounds 2, 1 and 3 (each within the scatter of the next, the first and the last beyond it); then compound 4.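

In this assay, among the compounds shown here, the open-chain isopropyl group gives the first measured change at this position that removes the ring without putting another in its place, and the number rises with a 2.4-fold higher number from compound 3 to compound 4 (0.37 log units; beyond the scatter). Set against the aromatic group, the same change gives a 7.0-fold higher number from compound 2 to compound 4 (0.85 log units; beyond the scatter), so among the three groups that can be compared here directly, phenyl in compound 2, cyclohexyl in compound 3 and isopropyl in compound 4, the numbers climb in that order, with each step beyond the usual scatter. Nothing measured here accounts for this rise, and the change from cyclohexyl to isopropyl removes a ring and lowers the carbon count at once, so the two cannot be told apart from these compounds alone.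

The compounds shown leave open whether a longer open chain such as n-hexyl would stay close to cyclohexyl or to isopropyl, and whether a smaller ring such as cyclopentyl would do the same. They also leave open how a chain carrying an amine or a carboxylic acid would read on this amide-type nitrogen, since every group here is built of carbon only.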